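The source may report more compounds than this note shows. Statements on the series, on what has been measured and on what is new or still open speak of the compounds shown alone.

Measured compounds:
- compound 1 `COc1ccc(C(=O)c2sc(Nc3ccc(C)cc3)c(C(=O)O)c2C)cc1`, "not active" (no number reported)
- compound 2 `COc1ccc(Nc2sc(C(=O)c3ccc(OC)cc3)c(C)c2C(=O)O)cc1`, 23.5%
- compound 3 `COc1ccc(C(=O)c2sc(Nc3ccc(F)cc3)c(C(=O)O)c2C)cc1`, 0.98%

In a functional assay, with a stated time of 150 min, tested at 10 ug/mL (a higher number here means a stronger effect of the compound at the concentration tested, a lower number a weaker effect), compound 1 is reported only as "not active" (no number reported), with no number attached, so it cannot be placed against compound 2 or compound 3 except as below both. Compound 4 `Cc1ccc(Nc2sc(C(=O)c3ccc(C)cc3)c(C)c2C(=O)O)cc1` differs from compound 1 by methyl in place of methoxy on an aromatic carbon. For the measured compounds named here, no measured step touches this ring: the single step known, a number 22.5 percentage points lower from compound 2 to compound 3 (beyond the scatter), concerns the other aromatic ring and a different exchange, so it gives no direct guide, only a sense that the series sits low overall. With compound 1 inactive and compound 3 at 0.98%, compound 4 is expected to stay low in this assay. The estimate for compound 4 is 6%, range 0% to 22%.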

Compound 4, a percentage reported as activity, at one concentration (the size of the read-out at that concentration, not a potency): "not active" (no number reported)
No number was reported for compound 4, and the estimate cannot be compared.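

In this assay compound 1 and compound 4 carry no number, and no step can be read between them. On these data alone, what the change from 4-methoxyphenyl to 4-methylphenyl does to the effect stays open. No evidence bears on this result.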